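The compounds below may be only part of what the source reports. "The series", "measured", "known", "first", "only" and "open" are said of these compounds alone.

Compound 2 `CC(C)OC(=O)N1CCC(Oc2ncnc3c2CCN3c2ccc(S(C)(=O)=O)nc2)CC1` gives the highest of the two numbers in a functional assay on CHO-K1 cells for agonist activity at Glucose-dependent insulinotropic receptor (Homo sapiens), read by a luciferase reporter, with a stated time of 5 h (a lower number here means that less compound is needed, a higher number that more compound is needed for the effect), at 251 nM. Compound 1 `CC(C)OC(=O)N1CCC(Oc2ncnc3c2CCN3c2ccc(S(C)(=O)=O)cc2F)CC1` gives 50.1 nM in this assay, and the step from a 5.0-fold higher number from compound 1 to compound 2 (0.70 log units; beyond the scatter) is the only one measured. Compound 3 `Cc1ncccc1N1CCc2c(OC3CCN(C(=O)OC(C)C)CC3)ncnc21` differs from compound 2 by 2-methylpyridin-3-yl in place of 6-(methylsulfonyl)pyridin-3-yl on a nitrogen on an aromatic ring in a ring. Among the compounds with values here, no measured step covers the removal of the methylsulfonyl group, so the step from compound 1 to compound 2 bears on it only by showing that this position moves the number. Compound 3 is expected to shift by a 3.2-fold higher number from compound 2 to compound 3 (0.50 log units; beyond the scatter), toward a higher number, with an estimate of 800 nM and a range from 200 nM to 4000 nM.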

Compound 3, half-maximal effective concentration: > 10000 nM
Compound 3 ended at the assay's limit; the forecaster's own chance of this, stated with the estimate: 10%; middle value at least 12-fold (1.09 log units) away from the limit.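

The reading for compound 3 is a limit of the assay and not a number: the limit of > 10000 nM in this assay, at which 1 of the 3 values shown sits. Even so, this position proves far more sensitive than the earlier step suggested, with an at least 39-fold higher number from compound 2 to compound 3 (1.60 log units; beyond the scatter) and an at least 190-fold higher number from compound 1 to compound 3 (2.30 log units; beyond the scatter). Among the compounds shown, only the two carrying a methylsulfonyl group give a measured value.

The change removes the methylsulfonyl group and adds the methyl group together, so the compounds shown do not separate the two. On these data alone, whether an amine or a carboxylic acid in place of the methylsulfonyl group would give a measurable value remains open.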